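Taking the Fluoro Group off Compound 3

The source may report more compounds than this note shows. Statements on the series, on what has been measured and on what is new or still open speak of the compounds shown alone.

In a functional assay on MIA PaCa-2 cells (Homo sapiens) for cytotoxicity, read by WST assay, with a stated time of 24 h (on this read-out higher numbers stand for weaker inhibition and lower numbers for stronger inhibition), compound 1 (`N#C/C(=C\c1c[nH]c2ccccc12)C(=O)c1c[nH]c2ccccc12`) gives a true number of 17900 nM for comparison. Compound 2 (`COc1ccc(Cn2cc(/C=C(\C#N)C(=O)c3c[nH]c4cc(OC)ccc34)c3ccccc32)cc1`) gives > 50000 nM and this is a limit, not a number. Compound 3 (`COc1ccc(Cn2cc(/C=C(\C#N)C(=O)c3c[nH]c4cc(F)ccc34)c3ccccc32)cc1`) gives > 50000 nM and this too is only a limit. Compound 3 thus stands at the limit of > 50000 nM in this assay, at which 2 of the 3 values shown sit, with no exact value known. Compound 4 (`COc1ccc(Cn2cc(/C=C(\C#N)C(=O)c3c[nH]c4ccccc34)c3ccccc32)cc1`) differs from it by hydrogen in place of fluoro on an aromatic carbon and has hydrogen in place of fluoro on an aromatic carbon. The nearest measured change is a step that the two limits leave unreadable from compound 2 to compound 3 and it offers no size to build on. The expected result in this assay is an at least 1.1-fold lower number from compound 3 to compound 4 (0.04 log units; that floor lies within the scatter) with little change and no firm direction. Compound 4 is estimated at 45000 nM within an expected range of 20000 nM to 100000 nM and may well return only a limit.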

Compound 4, half-maximal inhibitory concentration: > 50000 nM
Compound 4 was reported as a limit; the forecaster's own chance of this, stated with the estimate: 65%; at least 1.1-fold (0.04 log units) between middle value and limit.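

In this assay, compound 4 is also reported only as a limit, so hydrogen, fluoro and methoxy at this aromatic carbon cannot be ranked, and none of their steps can be read: the limit of > 50000 nM in this assay, at which 3 of the 4 values shown sit.

For the compounds shown here, the one readable step is an at least 2.7-fold higher number from compound 1 to compound 4 (0.44 log units; beyond the scatter), which isolates 4-methoxybenzyl in place of hydrogen on an aromatic nitrogen, a change no earlier pair showed alone.

From the compounds shown here alone, it remains open whether an amine or a carboxylic acid at this aromatic carbon would give a true number with 4-methoxybenzyl present. Going by these compounds, it is also open whether a methyl group on that nitrogen would behave like 4-methoxybenzyl.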